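This account rests on a few compounds, and the source may have more. Where it says the series, first, only, none or still open, it means among the compounds named here.

Measured in a functional assay on HT-29 cells (Homo sapiens) for cytotoxicity, read by MTT assay, with a stated time of 48 h; a lower number here means a stronger inhibitor, a higher number a weaker inhibitor:
- compound 1 `OC[C@@H]1C[C@H](CO)[C@@H]2C(c3ccc(Cl)cc3)=NO[C@H]12`: 22.9 ug/mL
- compound 2 `N#Cc1ccc(C2=NO[C@@H]3[C@H](CO)C[C@H](CO)[C@H]23)cc1`: > 50 ug/mL (a limit, not a number)
- compound 3 `OC[C@@H]1C[C@H](CO)[C@@H]2C(c3ccc4ccccc4c3)=NO[C@H]12`: 14.3 ug/mL

Compound 2 stands at the limit of > 50 ug/mL in this assay, at which 1 of the 3 values shown sits, so it has a limit and no number.

The next compound to be tested is compound 4 `OC[C@@H]1C[C@H](CO)[C@@H]2C(c3ccc(F)cc3)=NO[C@H]12`, which keeps the core of compound 2 and changes one group: fluoro in place of cyano on an aromatic carbon. In words, this puts fluoro in place of cyano on an aromatic carbon.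

Among the measured compounds shown here, one measured step bears on this change. Putting cyano in place of chloro at that same carbon gave an at least 2.1-fold higher number from compound 1 to compound 2 (0.33 log units; beyond the scatter). For the measured compounds named here, removing cyano from compound 2 may therefore reverse part or all of that step, although no fluoro compound has been measured yet. The expected change is an at least 1.6-fold lower number from compound 2 to compound 4 (0.22 log units; that floor lies within the scatter), a modest move towards a lower number. For compound 4 the estimated value is 30 ug/mL, with an expected range of 15 ug/mL to 50 ug/mL.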

Compound 4, half-maximal inhibitory concentration: 17.8 ug/mL
For compound 4 the middle estimate is 1.7-fold (0.23 log units) above the measured one, within the range that was stated.
By their numbers in this assay, from the lowest: compounds 3, 4 and 1 (each within the scatter of the next). At a limit, above all of these: compound 2.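

At this aromatic carbon, para to a large group, the result shows that the weak reading belongs to cyano, not to the position. Fluoro in place of cyano gives an at least 2.8-fold lower number from compound 2 to compound 4 (0.44 log units; beyond the scatter) in this assay, although compound 2 itself has only a limit and not a number: the limit of > 50 ug/mL in this assay, at which 1 of the 4 values shown sits. Fluoro in place of chloro gives a 1.3-fold lower number from compound 1 to compound 4 (0.11 log units; within the scatter), so these two halogens cannot be told apart here, and among the three groups at this carbon, cyano alone stands apart.

From the compounds shown here alone, the true size of the step from cyano to fluoro stays unknown, since only its floor can be read. Going by these compounds, it is also open whether cyano is a lone case, or whether a methoxy group, an amine or a carboxylic acid at this carbon would behave like cyano or like the halogens.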